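This account rests on a few compounds, and the source may have more. Where it says the series, first, only, none or still open, it means among the compounds named here.

Compounds measured so far:
- Compound 1, `C[C@H](O)[C@@H](CCc1cccc(F)c1)n1cnc2c(N)ncnc21`: 1.6 nM
- Compound 2, `C[C@H](O)[C@@H](CCc1cccc(Br)c1)n1cnc2c(N)ncnc21`: 0.6 nM
- Compound 3, `C[C@H](O)[C@@H](CCc1cccc(-c2cnccn2)c1)n1cnc2c(N)ncnc21`: 1.9 nM

These three share one core and differ only in the group carried on the outer aromatic ring. In an assay on isolated protein for inhibition of adenosine deaminase (Bos taurus), with a stated time of 5 min (on this read-out lower numbers stand for stronger inhibition and higher numbers for weaker inhibition), compound 1 gives 1.6 nM, which places it second highest of the three numbers; compound 3 sits close to it, as a 1.2-fold higher number from compound 1 to compound 3 (0.07 log units; within the scatter) shows, while compound 2 is further away, with a 2.7-fold lower number from compound 1 to compound 2 (0.43 log units; beyond the scatter).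

Compound 4, `C[C@H](O)[C@@H](CCc1cccc(C(N)=O)c1)n1cnc2c(N)ncnc21`, has not yet been measured. It differs from compound 1 in a single place: carbamoyl in place of fluoro on an aromatic carbon. Within the data shown here, no measured pair exchanges fluoro for a group of this kind. Among the measured compounds shown here, the two steps that start from compound 1 are the only guide: replacing fluoro by bromo gave a 2.7-fold lower number from compound 1 to compound 2 (0.43 log units; beyond the scatter), whereas replacing it by pyrazin-2-yl gave a 1.2-fold higher number from compound 1 to compound 3 (0.07 log units; within the scatter). For the measured compounds named here, a group with a hydrogen-bond donor and acceptor has no precedent here, so a step of at most modest size, more likely toward a higher number, is expected in this assay.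

For compound 4 the estimated value is 2.5 nM, in the range 0.8 nM to 8 nM, which would mean an expected step of a 1.6-fold higher number from compound 1 to compound 4 (0.19 log units; within the scatter).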

Compound 4, inhibition constant: 2.9 nM
Estimate against measurement, compound 4: 1.2-fold (0.06 log units) below, within the range that was stated.
By their numbers in this assay, from the lowest: compound 2; then compounds 1, 3 and 4 (each within the scatter of the next).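

Swapping fluoro for carbamoyl adds a hydrogen-bond donor and a hydrogen-bond acceptor on the aromatic ring, yet in this assay this gives a 1.8-fold higher number from compound 1 to compound 4 (0.26 log units; within the scatter) while replacing pyrazin-2-yl by carbamoyl gives a 1.5-fold higher number from compound 3 to compound 4 (0.18 log units; within the scatter) and neither step goes beyond the usual scatter. Compound 1, compound 3 and compound 4 therefore cannot be told apart, so this position accepts carbamoyl as well as it accepts fluoro or pyrazin-2-yl. Among these compounds, only the bromo group stands apart, with a 4.8-fold higher number from compound 2 to compound 4 (0.68 log units; beyond the scatter) as the one step for the new compound that is beyond the scatter, though still modest.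

From the compounds shown here alone, how an amine, a carboxylic acid or a longer chain at this position would read in this assay remains open. No measurement shown here offers a reason for any of these steps.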